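Moving the Hydroxyl Around the Pendant Phenyl Ring

A few compounds are considered here, and "the series" means these few. Any claim that something is new, unique, unknown or untested is made for them only; others in the source may bear on it.

Compound 1 `Oc1cccc(-c2cc(-c3ccccc3C(F)(F)F)cc(-c3ccccc3O)n2)c1`: 7250 nM in a functional assay on DU-145 cells (Homo sapiens) for inhibition; on this read-out higher numbers stand for weaker inhibition and lower numbers for stronger inhibition
Compound 2 `Oc1cccc(-c2cc(-c3ccccc3C(F)(F)F)cc(-c3cccc(O)c3)n2)c1`: 2870 nM in this assay

For the measured compounds named here, of the two numbers in this assay, compound 2 holds the lower one; the only step on record is a 2.5-fold lower number from compound 1 to compound 2 (0.40 log units; beyond the scatter). Compound 3 `Oc1ccc(-c2cc(-c3ccccc3C(F)(F)F)cc(-c3cccc(O)c3)n2)cc1` differs from compound 2 by 4-hydroxyphenyl in place of 3-hydroxyphenyl on an aromatic carbon. Going by the values given here, no measured pair covers this exact change; the step from compound 1 to compound 2 shows that shifting the hydroxyl on this ring can move the number modestly, but it says nothing about the move to 4-hydroxyphenyl. For compound 3 the expected step is therefore small, a 1.1-fold lower number from compound 2 to compound 3 (0.06 log units; within the scatter), with an estimate of 2500 nM and a range from 800 nM to 8000 nM.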

Compound 3, half-maximal inhibitory concentration: 2750 nM
Estimate against measurement, compound 3: 1.1-fold (0.04 log units) below; the range from low to high includes it.
By their numbers in this assay, from the lowest: compounds 3 and 2 (each within the scatter of the next); then compound 1.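

In this assay the hydroxyl on this ring gives a 1.0-fold lower number from compound 2 to compound 3 (0.02 log units; within the scatter) and so separates 4-hydroxyphenyl from 3-hydroxyphenyl by no more than the scatter. With a 2.6-fold lower number from compound 1 to compound 3 (0.42 log units; beyond the scatter) beside the earlier step, only the 2-hydroxyphenyl group of compound 1 stands apart at this position. Nothing available explains this difference.

The compounds shown leave open whether an amine or a carboxylic acid in place of the hydroxyl on this ring would hold the number. They also leave open what replacing the 2-(trifluoromethyl)phenyl group would do.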